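The compounds below may be only part of what the source reports. "The series", "measured", "known", "first", "only" and "open" are said of these compounds alone.

Among the measured compounds shown here, in a functional assay on K562 cells (Homo sapiens) for cytotoxicity, read by CCK-8 assay, with a stated time of 72 h (a lower number here means a stronger inhibitor, a higher number a weaker inhibitor), compound 1 `C=CCn1c(=O)/c(=C\c2cccc(Cl)c2)[nH]c(=O)/c1=C\c1ccccc1OC` gives 2700 nM, and compound 2 `C=CCn1c(=O)/c(=C\c2cccc(Cl)c2Cl)[nH]c(=O)/c1=C\c1ccccc1OC` gives 900 nM; compound 2 holds the lower of the two numbers, with a 3.0-fold lower number from compound 1 to compound 2 (0.48 log units; beyond the scatter) as the only step in the set. Compound 3 `C=CCn1c(=O)/c(=C\c2ccccc2C(F)(F)F)[nH]c(=O)/c1=C\c1ccccc1OC` carries 2-(trifluoromethyl)phenyl in place of 2,3-dichlorophenyl on a double-bonded chain carbon bound to an aromatic carbon. For the measured compounds named here, no measured step covers this exchange; the single step from compound 1 to compound 2 only shows that an added chloro lowered the number, and compound 3 gives up both chlorines, so a modest rise toward the number of compound 1 is expected, a 2.0-fold higher number from compound 2 to compound 3 (0.30 log units; within the scatter). Compound 3 is estimated at 1800 nM, within 600 nM to 5000 nM.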

Compound 3, half-maximal inhibitory concentration: 2700 nM
Estimate against measurement, compound 3: 1.5-fold (0.18 log units) below; the measured number falls inside the stated range.
By their numbers in this assay, from the lowest: compound 2; then compounds 1 and 3 (each within the scatter of the next).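

In this assay, at the double-bonded chain carbon bound to an aromatic carbon, 2-(trifluoromethyl)phenyl in place of 2,3-dichlorophenyl gives a 3.0-fold higher number from compound 2 to compound 3 (0.48 log units; beyond the scatter), matching in size the step gained with the added chloro. Against 3-chlorophenyl, the same group gives no change at the digits printed from compound 1 to compound 3 (within the scatter), so only 2,3-dichlorophenyl stands apart among these three groups. No evidence at hand gives a reason for these differences. Open, going by these compounds, is how an amine or a carboxylic acid on this aromatic ring would read, and whether these steps hold with other groups elsewhere on the shared core.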